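The source may report more compounds than this note shows. Statements on the series, on what has been measured and on what is new or still open speak of the compounds shown alone.

Measured compounds:
compound 1 `CCC[C@@H]1NC(=O)[C@@H](CCC(=O)O)NC(=O)[C@@H](Cc2ccc(O)cc2)NCCOc2ccccc2/C=C/CNC1=O`, 4900 nM
compound 2 `CCC[C@@H]1NC(=O)[C@@H](C(C)C)NC(=O)[C@@H](Cc2ccc(O)cc2)NCCOc2ccccc2CCCNC1=O`, 55 nM
compound 3 `CCC[C@@H]1NC(=O)[C@@H](C(C)C)NC(=O)[C@@H](Cc2ccc(O)cc2)NCCOc2ccccc2CCNC1=O`, 982 nM

In an assay on isolated protein for displacement of a labelled ligand from Motilin receptor (Homo sapiens) (on this read-out lower numbers stand for stronger inhibition and higher numbers for weaker inhibition), compound 2 gives the lowest number of the three; compound 3 stands higher by a step beyond the scatter, and compound 1 further still. Compound 4 `CCC[C@@H]1NC(=O)[C@@H](C(C)C)NC(=O)[C@@H](Cc2c[nH]c3ccccc23)NCCOc2ccccc2CCCNC1=O` is not yet measured. It differs from compound 2 in one place: 1H-indol-3-yl in place of 4-hydroxyphenyl on a saturated chain carbon bound to a saturated ring carbon. Among the compounds with values here, no measured pair shows this exchange, so its effect can only be expected, not read from the data. A change of this kind at the side chain is expected to cost some binding, with the step from compound 2 to compound 4 estimated as a modest rise, a 2.7-fold higher number from compound 2 to compound 4 (0.44 log units; beyond the scatter), likely beyond the scatter. Compound 4 is therefore estimated at 150 nM in this assay, within a range from 30 nM to 900 nM.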

Compound 4, inhibition constant: 255 nM
Compound 4: the middle estimate sits 1.7-fold (0.23 log units) below what was measured, within the range that was stated.
By their numbers in this assay, from the lowest: compound 2; then compound 4; then compound 3; then compound 1.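

On this side chain, 4-hydroxyphenyl can give way to the larger 1H-indol-3-yl, and in this assay the exchange brings a 4.6-fold higher number from compound 2 to compound 4 (0.67 log units; beyond the scatter) and so weakens binding without abolishing it. Compound 4 still keeps one hydrogen-bond donor on this group, though it has no hydrogen-bond acceptor there. Nothing available explains the rise in the number. From the compounds shown here alone, it remains open whether a plain phenyl or an amine in place of the hydroxyl would do better or worse here. A single exchange also cannot show whether the same step would appear with another group on the ring.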